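The source may hold more compounds than are shown below. What is called first, only, known or untested is meant among the compounds shown, and "the series" means these compounds.

The compounds share one core, seen in compound 2, `COc1cccc(NC(=O)Nc2cc(Oc3ccc4nc(NC(=O)C5CC5)sc4c3)ccc2F)c1`. In an ADME assay on HT-29 cells (Homo sapiens) for cytotoxicity, read by luminescence and CellTiter-Glo, with a stated time of 12 h (on this read-out higher numbers stand for lower toxicity in this test and lower numbers for higher toxicity in this test), compound 2 gives > 50000 nM; this is a limit of the assay, not a measured number. Its neighbour compound 1, `O=C(CCc1cccc(C(F)(F)F)c1)Nc1cc(Oc2ccc3nc(NC(=O)C4CC4)sc3c2)ccc1F`, carries a 2-(3-(trifluoromethyl)phenyl)ethyl group where compound 2 carries a (3-methoxyphenyl)amino group on the carbonyl carbon. In this assay compound 1 gives > 50000 nM, again a limit. The step that the two limits leave unreadable from compound 1 to compound 2 thus cannot be read in size or direction. All that the numbers show is the limit of > 50000 nM in this assay, at which 2 of the 2 values shown sit.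

Compound 3, `CC(=O)c1cccc(NC(=O)Nc2cc(Oc3ccc4nc(NC(=O)C5CC5)sc4c3)ccc2F)c1`, differs from compound 2 by acetyl in place of methoxy on an aromatic carbon. Within the data shown here, no measured step bears on this exchange, and both values in hand sit at the limit of the assay. The data give no hint of a change in toxicity for this exchange. The step from compound 2 to compound 3 in this assay is expected to be a step that the limit leaves unreadable from compound 2 to compound 3, within the usual scatter. Compound 3 is estimated at 100000 nM, between 30000 nM and 500000 nM, and its result is expected most likely to be reported again only as a limit.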

Compound 3, half-maximal cytotoxic concentration: > 50000 nM
Compound 3: no number, only a limit; the forecaster's own chance of this, stated with the estimate: 85%; the middle value lies beyond the limit too.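

Compound 3 gives only a limit as well, so the steps among compound 1, compound 2 and compound 3 cannot be read in size or direction: the limit of > 50000 nM in this assay, at which 3 of the 3 values shown sit.

Left open is whether any of these exchanges on the shared core changes the result in this assay at all, and what a measured number for any of the three compounds would be.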